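From compound 3 to compound 4: one aromatic group changes

The source may hold more compounds than are shown below. What is called first, only, known or untested is meant among the compounds shown, and "the series" means these compounds.

Measured so far in a functional assay on HeLa cells (Homo sapiens) for cytotoxicity, read by MTT assay, with a stated time of 48 h (on this read-out higher numbers stand for weaker inhibition and lower numbers for stronger inhibition), are three compounds
- compound 1 `Cc1ccc(C)c(/C=C/[C@](C)(O)CC[C@@H]2[C@@]3(C)CCCC(C)(C)[C@@H]3CC[C@@]2(C)O)c1` gives 3380 nM
- compound 2 `CC1(C)CCC[C@]2(C)[C@@H](CC[C@@](C)(O)/C=C/c3cncc4ccccc34)[C@](C)(O)CC[C@@H]12` gives 46000 nM
- compound 3 `Cc1cccc(/C=C/[C@](C)(O)CC[C@@H]2[C@@]3(C)CCCC(C)(C)[C@@H]3CC[C@@]2(C)O)c1C` gives 3700 nM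

Compound 3 shares its place on this scale with compound 1, and the two sit well apart from compound 2. The measured 1.1-fold higher number from compound 1 to compound 3 (0.04 log units; within the scatter) shows that moving from 2,5-dimethylphenyl to 2,3-dimethylphenyl changed nothing that can be told from the scatter. The a 12-fold lower number from compound 2 to compound 3 (1.09 log units; beyond the scatter) is large, and so is a 14-fold higher number from compound 1 to compound 2 (1.13 log units; beyond the scatter) in the opposite sense. Both large steps involve compound 2 and its isoquinolin-4-yl group.

The next compound is compound 4 `CC(C)(C)c1ccc(/C=C/[C@](C)(O)CC[C@@H]2[C@@]3(C)CCCC(C)(C)[C@@H]3CC[C@@]2(C)O)cc1` and it carries this change: 4-(tert-butyl)phenyl in place of 2,3-dimethylphenyl on a double-bonded chain carbon bound to a double-bonded chain carbon for the group that leaves and the group that enters. Like the two dimethylphenyl groups, 4-(tert-butyl)phenyl is a single six-membered aromatic ring of carbon only. Among the measured compounds shown here, the closest precedent is therefore a 1.1-fold higher number from compound 1 to compound 3 (0.04 log units; within the scatter) and not the steps that involve compound 2. For the measured compounds named here, no measured compound carries 4-(tert-butyl)phenyl, however, so this precedent is only indirect.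

The expected result is a 1.1-fold higher number from compound 3 to compound 4 (0.03 log units; within the scatter) and so no step beyond the scatter in this assay is anticipated. Compound 4 is expected at 4000 nM with an estimated range from 1500 nM to 12000 nM as its bounds.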

Compound 4, half-maximal inhibitory concentration: 48500 nM
The estimate for compound 4 lay 12-fold (1.08 log units) below the measured number, outside the stated range (above it).
By their numbers in this assay, from the lowest: compounds 1 and 3 (each within the scatter of the next); then compounds 2 and 4 (each within the scatter of the next).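

In this assay, the place on a double-bonded chain carbon bound to a double-bonded chain carbon now shows large steps even when the entering group is a single six-membered aromatic ring of carbon only: a 13-fold higher number from compound 3 to compound 4 (1.12 log units; beyond the scatter) and a 14-fold higher number from compound 1 to compound 4 (1.16 log units; beyond the scatter) mean that large steps are no longer tied to compound 2 and its isoquinolin-4-yl group. With a 1.1-fold higher number from compound 2 to compound 4 (0.02 log units; within the scatter), 4-(tert-butyl)phenyl and isoquinolin-4-yl cannot be told apart on this scale, so keeping a ring of carbon only does not by itself keep a compound level with the two dimethylphenyl compounds, compound 1 and compound 3. No independent information bears on the origin of these steps.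

The compounds shown leave open whether the step follows the size of the tert-butyl group or simply the presence of any group at the position it holds on the ring, a question that 4-methylphenyl and 4-isopropylphenyl would help to settle. Also open, from the compounds shown here alone, is where a phenyl ring carrying an amine or a carboxylic acid would fall on this scale.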